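A Small Change at One Carbonyl, Where Nothing Has Moved

The source may report more compounds than this note shows. Statements on the series, on what has been measured and on what is new or still open speak of the compounds shown alone.

Of the compounds shown here, three built on one shared core have been tested in an assay on isolated protein for inhibition of 2-Hydroxyacid oxidase 2 (Homo sapiens), tested at 1 uM; on this read-out higher numbers stand for a stronger effect at the one concentration tested and lower numbers for a weaker effect. Compound 1 `Cc1n[nH]c(C(=O)O)c1Cc1cccc(-c2ccccc2F)c1` gives 5%. Compound 2 `Cc1n[nH]c(C(=O)O)c1Cc1ccc(C#N)cc1` gives 0% in this assay. Compound 3 `Cc1n[nH]c(C(=O)O)c1Cc1ccc(C(N)=O)cc1` gives 0% in this assay. Compound 3 thus stands level with compound 2, and the value of compound 1 lies within the usual scatter of the value of compound 3, so none of the three can be set apart from the others on these numbers.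

For the measured compounds named here, the only measured step between close neighbours is no change at the digits printed from compound 2 to compound 3 (within the scatter). Compound 4 `Cc1n[nH]c(C(=O)O)c1Cc1ccc(C(=O)O)cc1` differs from compound 3 by hydroxy in place of amino on a carbonyl carbon. Going by the values given here, no measured pair exchanges hydroxy for amino, but the step from compound 2 to compound 3 already swapped one group on the same part of the molecule, carbamoyl in place of cyano on an aromatic carbon, and produced no change beyond the scatter. With all three measured values sitting near the bottom of the scale, the expectation is that compound 4 will also show no movement beyond the scatter, an estimated step of a number 2 percentage points higher from compound 3 to compound 4 (within the scatter). Compound 4 is therefore expected to give about 2% in this assay, with a likely range from -8% to 12%.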

Compound 4, a percentage reported as inhibition, at one concentration (the size of the read-out at that concentration, not a potency): 3%
Compound 4: the middle estimate sits 1 percentage points below what was measured; the measured number falls inside the stated range.
By their numbers in this assay, from the lowest: compounds 2, 3, 4 and 1 (each within the scatter of the next).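

Hydroxy in place of amino on the carbonyl carbon gives a step in this assay of a number 3 percentage points higher from compound 3 to compound 4 (within the scatter) and so does not set compound 4 apart from compound 3. The carboxy group can also be compared directly with the nitrile, and the step of a number 3 percentage points higher from compound 2 to compound 4 (within the scatter) leaves those two compounds just as hard to tell apart. Nitrile, carbamoyl and carboxy at this aromatic carbon therefore give three numbers that all lie within the scatter of one another, which is more than the single earlier swap could show, though the pattern reaches only as far as compounds 2, 3 and 4, and no supporting measurement offers any explanation for it.

On these data alone, it stays open whether a different kind of group at this place, such as an aminomethyl group, a sulfonamide or a methyl ester, would lift the number clear of the scatter. Because each compound was read at one concentration, these numbers also leave open how the compounds would compare at higher concentrations, where a difference might appear.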